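A Methoxy Added to the Ethoxy Chain

The compounds below may be only part of what the source reports. "The series", "measured", "known", "first", "only" and "open" are said of these compounds alone.

Compound 3 `CCOc1nc(N)nc2c1ncn2/C=C1/CC1(CO)CO` carries an ethoxy group on the shared core. In an ADME assay on MOLT-3 cells (Homo sapiens) for cytotoxicity, with a stated time of 7 days (on this read-out lower numbers stand for higher toxicity in this test and higher numbers for lower toxicity in this test), compound 3 gives > 20000 nM, which is a limit and not a number. In this assay compound 1 `Nc1nc(OCC(F)(F)F)c2ncn(/C=C3/CC3(CO)CO)c2n1` gives > 20000 nM, also a limit. For compound 2 `CC(C)CSc1nc(N)nc2c1ncn2/C=C1/CC1(CO)CO` the entry reads "not determined" (no result reported). Among the measured compounds shown here, the series so far therefore offers (the limit of > 20000 nM in this assay, at which 2 of the 3 values shown sit).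

Compound 4 `COCCOc1nc(N)nc2c1ncn2/C=C1/CC1(CO)CO` turns the ethoxy into 2-methoxyethoxy, with methoxy in place of hydrogen on a saturated chain carbon, two bonds along the chain from an oxygen on an aromatic ring.

For the measured compounds named here, the only measured step that bears on this change is a step that the two limits leave unreadable from compound 1 to compound 3, so it gives no size to carry over. Because compound 3 shows only the limit > 20000 nM, no step beyond the scatter is expected for compound 4, and a further limit is the likeliest report. The expected step is a step that the limit leaves unreadable from compound 3 to compound 4. The estimated value for compound 4 is 25000 nM, with an expected range of 10000 nM to 60000 nM.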

Compound 4, half-maximal cytotoxic concentration: > 20000 nM
Compound 4 ended at the assay's limit; the forecaster's own chance of this, stated with the estimate: 85%; the middle value is on the limit's open side.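

Among the compounds shown here, no step between compound 1, compound 3 and compound 4 can be read in this assay, because all three are reported only as a limit: the limit of > 20000 nM in this assay, at which 3 of the 4 values shown sit. The compounds shown leave open whether these three truly differ in toxicity, and by how much.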